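Chain shortening on the saturated azetidine amide

A few compounds are considered here, and "the series" means these few. Any claim that something is new, unique, unknown or untested is made for them only; others in the source may bear on it.

Measured so far:
compound 1 `CCCCCCCC/C=C\CCCCCCCC(=O)N1CCCCC1`: 7.7 ug/mL
compound 2 `CCCCCCCCCCCCCCCCCC(=O)N1CCCC1`: 7.1 ug/mL
compound 3 `CCCCC/C=C\C/C=C\CCCCCCCC(=O)N1CCCCC1`: 63.2 ug/mL

In a functional assay on NCI/ADR-RES cells (Homo sapiens) for antiproliferative activity, read by sulforhodamine B assay, with a stated time of 48 h (a higher number here means a weaker inhibitor of growth, a lower number a stronger inhibitor of growth), compound 2 gives the lowest of the three numbers. Compound 1 sits within the scatter of it, whereas compound 3 sits far above it. Going by the values given here, the only single-point step measured, an 8.2-fold higher number from compound 1 to compound 3 (0.91 log units; beyond the scatter), concerns unsaturation within the chain and says nothing about chain length.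

Compound 4 `CCCCCCCCCCCCCCCC(=O)N1CCCC1` is the next member: hydrogen in place of ethyl on a saturated chain carbon, ten or more bonds along the chain from a carbonyl carbon. Among the compounds with values here, no measured pair covers a change of this kind, so there is no basis for expecting a step beyond the scatter in this assay; the expected step is a 1.1-fold higher number from compound 2 to compound 4 (0.05 log units; within the scatter). Compound 4 is therefore estimated at 8 ug/mL, with a range of 4 ug/mL to 16 ug/mL.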

Compound 4, concentration for 50% growth inhibition: 4.6 ug/mL
Compound 4: middle estimate off by 1.7-fold (0.24 log units), on the high side; the range from low to high includes it.
By their numbers in this assay, from the lowest: compounds 4, 2 and 1 (each within the scatter of the next); then compound 3.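

In this assay, hydrogen in place of ethyl on a saturated chain carbon, ten or more bonds along the chain from a carbonyl carbon, gives a 1.5-fold lower number from compound 2 to compound 4 (0.19 log units; within the scatter), so compound 2 and compound 4 cannot be told apart. This position therefore tolerates this change in the chain, at least for this single pair. No evidence bearing on this result is available.

Going by these compounds, whether a much shorter chain would behave the same stays open. So does the effect of a carboxylic acid or an amine at this position.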